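Two limits and a hydroxy swap still to test

A few compounds are considered here, and "the series" means these few. Any claim that something is new, unique, unknown or untested is made for them only; others in the source may bear on it.

In a functional assay on FM3A cells (Mus musculus), with a stated time of 2 days (a higher number here means a weaker inhibitor, a lower number a stronger inhibitor), compound 1 `C=C1C=CCO[C@@H]1n1cc(C)c(O)nc1=O` gives only a limit of >= 900000 nM and no exact number. Compound 2 `C=C1C=CCO[C@@H]1n1ccc(N)nc1=O` likewise stands at a limit of >= 1800000 nM and has no exact number either. Compound 3 `C=C1C=CCO[C@@H]1n1ccc(O)nc1=O` carries hydroxy in place of amino on an aromatic carbon. Among the compounds with values here, no measured pair shows this swap, so no step beyond the scatter is expected in this assay (expected: an at least 1.2-fold lower number from compound 2 to compound 3 (0.07 log units; that floor lies within the scatter)). Compound 1 also carries a hydroxy group and still gives a limit (>= 900000 nM), which supports this expectation. The estimate for compound 3 is 1500000 nM (expected range 500000 nM to 3000000 nM), possibly reported only as a limit.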

Compound 3, half-maximal inhibitory concentration: > 1000000 nM
Compound 3: a limit, no number (the forecaster's own chance of this, stated with the estimate: 85%); the middle value lies beyond the limit too.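

Within the data shown here, compound 1, compound 2 and compound 3 all stand only as limits in this assay, so no step between them can be read. From the compounds shown here alone, whether either swap, hydroxy in place of amino or hydrogen in place of methyl, changes inhibition remains open.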